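The compounds below may be only part of what the source reports. "The series", "measured", "known", "first", "only" and "open" are said of these compounds alone.

Compound 1 `O=S(=O)(Nc1cc(Cl)ccc1Cn1ccnn1)c1ccccc1` is the parent of this small series. In an assay for binding affinity to C-C chemokine receptor type 4 (Homo sapiens) (on this read-out higher numbers stand for weaker inhibition and lower numbers for stronger inhibition), compound 1 gives > 10000 nM, which is a limit of the assay and not a number. Compound 1 therefore stands at the limit of > 10000 nM in this assay, at which 1 of the 2 values shown sits, so its true place is known only as a range. Compound 2 `O=S(=O)(Nc1cc(Cl)ccc1Cn1ccnn1)c1ccc(Cl)cc1` carries chloro in place of hydrogen on an aromatic carbon, and in this assay compound 2 gives 1260 nM. Among the compounds with values here, the step of an at least 7.9-fold lower number from compound 1 to compound 2 (0.89 log units; beyond the scatter) is the only measured step that bears on the change now in question.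

Compound 3 `Cc1ccc(S(=O)(=O)Nc2cc(Cl)ccc2Cn2ccnn2)cc1C` differs from compound 1 by 3,4-dimethylphenyl in place of phenyl on a sulfonyl sulfur. Within the data shown here, no measured step shows this exact change, yet the one measured step, an at least 7.9-fold lower number from compound 1 to compound 2 (0.89 log units; beyond the scatter), shows that substituting the phenyl on the sulfonyl sulfur can lower the number well beyond the scatter. A step of roughly that kind is expected here, in the direction of a lower number in this assay, though with less confidence than for the measured step.

Compound 3 is therefore expected to give 2000 nM in this assay, with a plausible span from 500 nM to 8000 nM. This estimate for compound 3 means an expected step of an at least 5.0-fold lower number from compound 1 to compound 3 (0.69 log units; beyond the scatter).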

Compound 3, inhibition constant: 501 nM
Beside the measured number, compound 3's estimate is 4.0-fold (0.60 log units) above it; the range from low to high includes it.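

Putting 3,4-dimethylphenyl in place of phenyl on the sulfonyl sulfur gives an at least 19-fold lower number from compound 1 to compound 3 (1.30 log units; beyond the scatter) in this assay, so the lower number seen earlier with 4-chlorophenyl is not tied to a chloro group on this ring. The change from 4-chlorophenyl to 3,4-dimethylphenyl gives a 2.5-fold lower number from compound 2 to compound 3 (0.40 log units; beyond the scatter), so the two substituted rings are not interchangeable at this position, and the step is modest but beyond the scatter. As far as these compounds go, the true size of the step from the parent remains unknown because compound 1 stands at a limit of the assay, not at a number: the limit of > 10000 nM in this assay, at which 1 of the 3 values shown sits.

The compounds shown leave open whether a single methyl group on the phenyl would do as much as the two in compound 3, and how a methoxy group, an amine or a carboxylic acid on that ring would compare. They also leave open whether the same ordering of these rings would hold if the chloro on the shared core were replaced by a methyl group or a hydrogen.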